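The compounds below may be only part of what the source reports. "The series", "measured", "known", "first", "only" and "open" are said of these compounds alone.

Compound 1 `CC1=C(O)C(C)(C)c2oc(-c3ccccc3)cc(=O)c2C1=O` gives > 40 ug/mL in a functional assay on KB cells (Homo sapiens) for cytotoxicity, read by sulforhodamine B assay; on this read-out lower numbers stand for an effect already at smaller amounts and higher numbers for an effect only at larger amounts of compound; this is a limit of the assay, not a number.
Compound 2 `CCC1=C(O)c2c(oc(-c3ccccc3)cc2=O)C(CC)(CC)C1=O` gives > 80 ug/mL in this assay; this too is a limit, not a number.

For the measured compounds named here, neither measured compound therefore has a definite value, and no step between them can be read. Compound 2 stands at the limit of > 80 ug/mL in this assay, at which 1 of the 2 values shown sits, and the other measured compound stands at the limit of > 40 ug/mL in this assay, at which 1 of the 2 values shown sits, so on the numbers shown compound 2 is simply not yet seen to act at the amounts tested.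

Compound 3 `CCC1=C(O)c2c(oc(-c3ccc(C)cc3)cc2=O)C(CC)(CC)C1=O` differs from compound 2 by methyl in place of hydrogen on an aromatic carbon. Going by the values given here, with no measured step to lean on, nothing points to a change beyond the usual scatter, and the expected step is a step that the limit leaves unreadable from compound 2 to compound 3. Compound 3 is accordingly expected to give about 100 ug/mL, between 40 ug/mL and 300 ug/mL, most likely again only as a limit.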

Compound 3, concentration for half-maximal effect: 13.8 ug/mL
Compound 3: the middle estimate sits 7.2-fold (0.86 log units) above what was measured; measured number outside the range, below it.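

In this assay, the change from phenyl to 4-methylphenyl yields the first definite value among the compounds shown, with an at least 5.7-fold lower number from compound 2 to compound 3 (0.76 log units; beyond the scatter). This position on the aromatic ring therefore matters: one added methyl, para to a large group, is enough to bring a measurable effect on these cells. The true size of the step remains unknown, because compound 2 gives only a limit and not a number: the limit of > 80 ug/mL in this assay, at which 1 of the 3 values shown sits.

With only hydrogen and methyl shown at this place, it remains open whether methyl is special or whether an ethyl chain, a methoxy group, a chlorine atom or an amine would serve as well or better. On these data alone, it also remains open whether the same methyl would have a similar effect on the core of compound 1.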